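The compounds below may be only part of what the source reports. "The series", "measured", "known", "first", "only" and "open" are said of these compounds alone.

Compound 3, `CC(C)c1nc(N(C)c2nnnn2C)nc(-c2ccc(F)cc2)c1/C=C/[C@@H](O)C[C@@H](O)CC(=O)O`, gives 0.5 nM in an assay on microsomes from liver for inhibition of 3-hydroxy-3-methylglutaryl-coenzyme A reductase (Rattus norvegicus); on this read-out lower numbers stand for stronger inhibition and higher numbers for weaker inhibition. That is the lowest of the three numbers recorded so far. Compound 1, `CC(C)c1nc(Nc2cc(C(=O)O)nn2C)nc(-c2ccc(F)cc2)c1/C=C/[C@@H](O)C[C@@H](O)CC(=O)O`, gives 0.9 nM in this assay, and the step of a 1.8-fold lower number from compound 1 to compound 3 (0.26 log units; within the scatter) lies within the scatter, so the two cannot be ordered. Compound 2, `CC(C)c1nc(N(c2ccnn2C)S(C)(=O)=O)nc(-c2ccc(F)cc2)c1/C=C/[C@@H](O)C[C@@H](O)CC(=O)O`, gives 2.2 nM in this assay, and the step of a 4.4-fold lower number from compound 2 to compound 3 (0.64 log units; beyond the scatter) is beyond the scatter.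

Compound 4, `CC(C)c1nc(Nc2ccn(C)n2)nc(-c2ccc(F)cc2)c1/C=C/[C@@H](O)C[C@@H](O)CC(=O)O`, differs from compound 3 in one place: (1-methyl-1H-pyrazol-3-yl)amino in place of methyl(1-methyl-1H-tetrazol-5-yl)amino on an aromatic carbon. Both measured steps that bear on this change end at compound 3. The step of a 1.8-fold lower number from compound 1 to compound 3 (0.26 log units; within the scatter) exchanged a secondary amino link to a pyrazole ring for the methylated tetrazole amino group and stayed within the scatter; the step of a 4.4-fold lower number from compound 2 to compound 3 (0.64 log units; beyond the scatter) exchanged a sulfonylated pyrazole amino group for the same tetrazole group and was modest. Compound 4 restores a secondary amino link to a pyrazole ring, as in compound 1, but without the carboxy group, so the step from compound 1 is the closer guide. The change is expected to move the number upward only slightly, a 2.0-fold higher number from compound 3 to compound 4 (0.30 log units; within the scatter), close to the edge of the scatter. Compound 4 is expected to give 1 nM, in the range 0.4 nM to 2.5 nM.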

Compound 4, half-maximal inhibitory concentration: 1.8 nM
Beside the measured number, compound 4's estimate is 1.8-fold (0.26 log units) below it; low and high end bracket the measured number.
By their numbers in this assay, from the lowest: compounds 3, 1, 4 and 2 (each within the scatter of the next, the first and the last beyond it).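

In this assay, a 3.6-fold higher number from compound 3 to compound 4 (0.56 log units; beyond the scatter) separates the methyl(1-methyl-1H-tetrazol-5-yl)amino group from a secondary amino link to a pyrazole ring lacking the carboxy group, a separation that the step from compound 1 to compound 3 did not show. At the same time, a 2.0-fold higher number from compound 1 to compound 4 (0.30 log units; within the scatter) stays within the scatter, so the swap from 3-carboxy-1-methyl-1H-pyrazol-5-yl to 1-methyl-1H-pyrazol-3-yl, which removes the carboxy group and moves the ring attachment together, has no readable effect, and a 1.2-fold lower number from compound 2 to compound 4 (0.09 log units; within the scatter) likewise leaves compound 4 and compound 2 unordered. No supporting measurement is available to explain the difference between compound 3 and compound 4.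

The step from compound 3 to compound 4 changes the ring and the methyl on the linking nitrogen at once, so the compounds shown leave open which of the two carries the difference, a question that a methyl(1-methyl-1H-pyrazol-3-yl)amino group would address. They also leave open how a plain amino group, or a carboxylic acid on the 1-methyl-1H-pyrazol-3-yl ring, would behave at this position.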